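Dichlorophenyl Rearrangement on a Shared Amide Nitrogen

This account rests on a few compounds, and the source may have more. Where it says the series, first, only, none or still open, it means among the compounds named here.

Compound 1 `CC(Sc1nnc(-c2ccncc2)s1)C(=O)Nc1ccc(Cl)cc1Cl` is assessed in an ADME assay on BHK-21 cells (Mesocricetus auratus) for cytotoxicity, with a stated time of 3 days; on this read-out higher numbers stand for lower toxicity in this test and lower numbers for higher toxicity in this test. Compound 1 reaches only the assay limit of > 50000 nM. Compound 2 `CC(Sc1nnc(-c2ccncc2)s1)C(=O)NCc1ccccc1Cl` likewise stops at the limit of > 50000 nM. Compound 3 `CC(Sc1nnc(-c2ccncc2)s1)C(=O)Nc1ccccc1` also returns the limit of > 50000 nM. Because of the limit of > 50000 nM in this assay, at which 3 of the 3 values shown sit, the change from compound 1 to compound 2 is a step that the two limits leave unreadable from compound 1 to compound 2 and that from compound 1 to compound 3 is a step that the two limits leave unreadable from compound 1 to compound 3. Compound 4 `CC(Sc1nnc(-c2ccncc2)s1)C(=O)Nc1c(Cl)cccc1Cl` differs from compound 1 by 2,6-dichlorophenyl in place of 2,4-dichlorophenyl on an amide-type nitrogen. The two measured steps that alter the same amide-type nitrogen bear on this one, yet neither has a readable size, so no step beyond the scatter can be foreseen in this assay. Compound 4 is therefore expected to sit near 80000 nM, between 40000 nM and 200000 nM, an expected step that the limit leaves unreadable from compound 1 to compound 4.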

Compound 4, half-maximal cytotoxic concentration: > 50000 nM
Compound 4 gave a limit, no number; the forecaster's own chance of this, stated with the estimate: 85%; the middle value does not contradict the limit.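

The steps linking compound 4 with compounds 1, 2 and 3 cannot be read in this assay, and the cause is shared: the limit of > 50000 nM in this assay, at which 4 of the 4 values shown sit.

The compounds shown leave open whether any of these changes on the amide-type nitrogen alters cytotoxicity at all.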